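Sulfonamide nitrogen alkyl step in the acid-bearing series

This account rests on a few compounds, and the source may have more. Where it says the series, first, only, none or still open, it means among the compounds named here.

The series shares one core, carried by compound 1 `CN(c1ccccc1)S(=O)(=O)C1CC2OC1C(c1ccc(NC(=O)CCCCCCC(=O)O)cc1)=C2c1ccc(O)cc1`, compound 2 `Cc1ccc(N(C)S(=O)(=O)C2CC3OC2C(c2ccc(NC(=O)CCCCCCC(=O)O)cc2)=C3c2ccc(O)cc2)cc1` and compound 3 `Cc1cccc(N(C)S(=O)(=O)C2CC3OC2C(c2ccc(NC(=O)CCCCCCC(=O)O)cc2)=C3c2ccc(O)cc2)c1`. In a functional assay on DU-145 cells (Homo sapiens) for antiproliferative activity, read by MTT assay, with a stated time of 72 h (a higher number here means a weaker inhibitor, a lower number a stronger inhibitor), compound 1 gives > 100000 nM, a limit of the assay. In this assay compound 2 gives > 100000 nM, likewise a limit. In this assay compound 3 gives > 100000 nM, again a limit and not a number. Compound 3 thus stands at the limit, as do the two others; all three values sit at the limit of > 100000 nM in this assay, at which 3 of the 3 values shown sit. The steps a step that the two limits leave unreadable from compound 1 to compound 2, a step that the two limits leave unreadable from compound 1 to compound 3 and a step that the two limits leave unreadable from compound 2 to compound 3, each running between two limits, are unreadable in size.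

Compound 4 `CCN(c1cccc(C)c1)S(=O)(=O)C1CC2OC1C(c1ccc(NC(=O)CCCCCCC(=O)O)cc1)=C2c1ccc(O)cc1` is the next member. It differs from compound 3 by methyl in place of hydrogen on a saturated chain carbon bound to a sulfonamide nitrogen. Going by the values given here, no measured step reads this change; the three steps that exist are unreadable, and none of them touches the saturated chain carbon bound to the sulfonamide nitrogen. They show only that methyl in place of hydrogen on an aromatic carbon and 3-methylphenyl in place of 4-methylphenyl left every compound at the limit. The expectation for compound 4 is no readable step, a step that the limit leaves unreadable from compound 3 to compound 4, with a limit the most probable outcome. Compound 4 is estimated at 150000 nM, in the range 30000 nM to 800000 nM.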

Compound 4, half-maximal inhibitory concentration: 65600 nM
Estimate against measurement, compound 4: 2.3-fold (0.36 log units) above, and the stated range covers the measured number.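

In this assay, methyl in place of hydrogen on a saturated chain carbon bound to a sulfonamide nitrogen is the first change in the series to give a number rather than a limit, with compound 4 at 65600 nM, while the other values stay where they were: the limit of > 100000 nM in this assay, at which 3 of the 4 values shown sit.

The change reads as an at least 1.5-fold lower number from compound 3 to compound 4 (0.18 log units; that floor lies within the scatter), and the wider replacements read as an at least 1.5-fold lower number from compound 2 to compound 4 (0.18 log units; that floor lies within the scatter) and an at least 1.5-fold lower number from compound 1 to compound 4 (0.18 log units; that floor lies within the scatter); all three are floors and not sizes, so none of them shows a gain beyond the scatter. Going by these compounds alone, the steps among compound 1, compound 2 and compound 3 cannot be read, which leaves ethyl on the sulfonamide nitrogen as the only change here that gives a step with any readable floor.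

Going by these compounds, whether a longer chain on the sulfonamide nitrogen, such as propyl or butyl, would move the number in this assay remains open. Also open, on these data alone, is whether ethyl on that nitrogen gives a number alongside the 4-methylphenyl or the unsubstituted phenyl group, or whether an amine at the end of that chain would keep one.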